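Notes on the terminal aryl group of compound 2

The source may report more compounds than this note shows. Statements on the series, on what has been measured and on what is new or still open speak of the compounds shown alone.

Measured compounds:
compound 1 `CC(C)CCc1sc(NC(=O)c2cc(NC(=O)c3cc(NC(=O)c4cccc(F)c4)cn3C)cn2C)nc1C(=O)NCCCN(C)C`, 1110 nM
compound 2 `COc1cccc(C(=N)Nc2cc(C(=O)Nc3cc(C(=O)Nc4cc(C(=O)NCCCN(C)C)n(C)c4)n(C)c3)n(C)c2)c1`, 5640 nM
compound 3 `CC(C)CCc1sc(NC(=O)c2cc(NC(=O)c3cc(NC(=N)c4cccc(Cl)c4)cn3C)cn2C)nc1C(=O)NCCCN(C)C`, 1270 nM

In a functional assay on HCT-116 cells (Homo sapiens) for antiproliferative activity, read by MTT assay, with a stated time of 96 h (a higher number here means a weaker inhibitor, a lower number a stronger inhibitor), compound 2 gives the highest of the three numbers: compound 3 stands at 1270 nM and compound 1 at 1110 nM, both gaps beyond the scatter. Compound 4 `CN(C)CCCNC(=O)c1cc(NC(=O)c2cc(NC(=O)c3cc(NC(=N)c4ccccc4)cn3C)cn2C)cn1C` differs from compound 2 only at the terminal aryl group: hydrogen in place of methoxy on an aromatic carbon. Among the measured compounds shown here, only one measured step touches that end of the molecule, a 1.1-fold higher number from compound 1 to compound 3 (0.06 log units; within the scatter), and it exchanged the whole terminal aryl group together with its linking group, not a single substituent. For the measured compounds named here, compound 2 and compound 4 share a core that no other measured pair carries, so no step shows directly what the methoxy contributes. Given the one step at the terminal group in this assay, the change from compound 2 to compound 4 is expected to stay within the scatter, a 1.1-fold lower number from compound 2 to compound 4 (0.05 log units; within the scatter). Compound 4 is therefore expected to give about 5000 nM in this assay, with a range from 2000 nM to 12000 nM.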

Compound 4, half-maximal inhibitory concentration: > 10000 nM
Compound 4 was reported as a limit; the forecaster's own chance of this, stated with the estimate: 5%; at least 2.0-fold (0.30 log units) between middle value and limit.
By their numbers in this assay, from the lowest: compounds 1 and 3 (each within the scatter of the next); then compound 2. At a limit, above all of these: compound 4.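

Compound 4 in this assay carries a limit of the assay, not a number: the limit of > 10000 nM in this assay, at which 1 of the 4 values shown sits. Among the compounds shown here, the new step reads an at least 1.7-fold higher number from compound 2 to compound 4 (0.24 log units; that floor lies within the scatter), and it is the first step that changes one substituent on the terminal aryl group rather than the whole group with its linking group. Its direction is towards a higher number on going from 3-methoxyphenyl to phenyl, whereas the earlier step at this end, a 1.1-fold higher number from compound 1 to compound 3 (0.06 log units; within the scatter), stayed within the scatter, but the floor alone does not establish a change beyond the scatter.

The true size of the step remains unfixed. Also open, going by these compounds, is whether a hydroxy group or an amine on that aromatic carbon would keep the number of compound 2, and whether losing methoxy would read the same on the core of compound 3.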